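The compounds below may be only part of what the source reports. "The series", "measured", "known", "first", "only" and "open" are said of these compounds alone.

In a functional assay on HeLa cells (Homo sapiens) for antiproliferative activity, read by sulforhodamine B assay (on this read-out lower numbers stand for stronger inhibition and higher numbers for weaker inhibition), compound 1 (`c1ccc(/C(=N/Nc2nc3ccccc3o2)C2CC2)nc1`) gives 4490 nM, the higher of the two numbers available, while compound 2 (`c1ccc(C(=NNc2nc3ccccc3o2)c2ccccn2)nc1`) gives 156 nM, a gap beyond the scatter. Compound 3 (`CCC/C(=N\Nc1nc2ccccc2o1)c1ccccn1`) has not yet been measured. It carries propyl in place of cyclopropyl on a carbon with a double bond to nitrogen. For the measured compounds named here, no measured pair shows this change, so in this assay no step beyond the scatter is expected, and no firm direction. The estimated step is a 1.5-fold lower number from compound 1 to compound 3 (0.18 log units; within the scatter). For compound 3 the expected value is 3000 nM, with an estimated range of 1000 nM to 9000 nM.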

Compound 3, half-maximal inhibitory concentration: 153 nM
For compound 3 the middle estimate is 20-fold (1.29 log units) above the measured one; measured number outside the range, below it.
By their numbers in this assay, from the lowest: compounds 3 and 2 (each within the scatter of the next); then compound 1.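

Measured in this assay, propyl in place of cyclopropyl on this carbon gives a 29-fold lower number from compound 1 to compound 3 (1.47 log units; beyond the scatter), although both groups hold 3 carbon atoms, so this position distinguishes a ring from an open chain of the same size. Compound 3 at 153 nM and compound 2 at 156 nM lie within the scatter of each other. Nothing available explains this step.

Open, from the compounds shown here alone, is whether a longer chain such as butyl, or a branched group such as isopropyl, would keep this level. Going by these compounds, it is equally open how an amine at this place would behave.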